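Swapping a sulfinic acid for a butoxysulfonyl group

The compounds below may be only part of what the source reports. "The series", "measured", "known", "first", "only" and "open" are said of these compounds alone.

Compound 2, `CCC(CC)O[C@@H]1C=C([S+]([O-])O)C[C@H](NC(=N)N)[C@H]1NC(C)=O`, and compound 1, `CCC(CC)O[C@@H]1C=C([B-](F)(F)F)C[C@H](NC(=N)N)[C@H]1NC(C)=O`, share the same core; in an ADME assay on MDCK cells (Canis lupus familiaris) for cytotoxicity, with a stated time of 48 h (a lower number here means that less compound is tolerated, a higher number that more compound is tolerated), compound 1 gives "not determined" (no result reported). In this assay compound 2 gives only the limit > 100000 nM, a boundary of the measurement rather than a number. It therefore stands at the limit of > 100000 nM in this assay, at which 1 of the 2 values shown sits. Compound 3, `CCCCOS(=O)(=O)C1=C[C@@H](OC(CC)CC)[C@H](NC(C)=O)[C@@H](NC(=N)N)C1`, carries the change (a group of 8 heavy atoms (4 carbon, 3 oxygen, 1 sulfur; no ring) in place of a group of 3 heavy atoms (2 oxygen, 1 sulfur; no ring), on a double-bonded ring carbon). For the measured compounds named here, with no measured step to lean on and compound 2 already at the limit, no change beyond the scatter is expected. Compound 3 is estimated at 120000 nM, between 40000 nM and 400000 nM, an expected step that the limit leaves unreadable from compound 2 to compound 3.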

Compound 3, half-maximal cytotoxic concentration: > 100000 nM
Compound 3: a limit, no number; the forecaster's own chance of this, stated with the estimate: 70%; the middle value does not contradict the limit.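

Compound 2 and compound 3 both sit at a limit rather than a number, so no step between them can be read, because the measurement stops there: the limit of > 100000 nM in this assay, at which 2 of the 3 values shown sit.

Going by these compounds, whether the butoxysulfonyl group changes cytotoxicity at all remains open, as does the concentration at which either compound would harm the cells.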